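The source may report more compounds than this note shows. Statements on the series, on what has been measured and on what is new or still open speak of the compounds shown alone.

In a functional assay on A549 cells (Homo sapiens) for antiproliferative activity, read by MTT assay, with a stated time of 48 h (on this read-out higher numbers stand for weaker inhibition and lower numbers for stronger inhibition), compound 1 (`C#CCOC(=O)/C(C)=C/CC/C(C)=C/CC/C(C)=C/CC[C@@H]1[C@@]2(C)CCC(=O)C(C)(C)[C@H]2CC[C@@]1(C)O`) gives 45100 nM. Compound 2 (`C/C(=C\CC/C(C)=C/CC[C@@H]1[C@@]2(C)CCC(=O)C(C)(C)[C@H]2CC[C@@]1(C)O)CC/C=C(\C)C(=O)OCc1cn(-c2cccc(C(F)(F)F)c2)nn1`) is reported only as a limit, > 150000 nM. Compound 3 (`C/C(=C\CC/C(C)=C/CC[C@@H]1[C@@]2(C)CCC(=O)C(C)(C)[C@H]2CC[C@@]1(C)O)CC/C=C(\C)C(=O)OCc1cn(-c2cccc(O)c2)nn1`) has hydroxy in place of trifluoromethyl on an aromatic carbon, meta to a large group: hydroxy in place of trifluoromethyl on an aromatic carbon. A modest move toward stronger inhibition in this assay is expected, with an estimated at least 1.6-fold lower number from compound 2 to compound 3 (0.22 log units; that floor lies within the scatter), though a second result at the limit remains possible. Among the compounds with values here, the only true number to lean on is that of compound 1, 45100 nM. For compound 3 the expected value is 90000 nM, with an estimated range of 35000 nM to 200000 nM.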

Compound 3, half-maximal inhibitory concentration: 42800 nM
Compound 3: middle estimate off by 2.1-fold (0.32 log units), on the high side, within the range that was stated.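

In this assay, the change from 3-(trifluoromethyl)phenyl to 3-hydroxyphenyl gives the series its first step beyond the scatter, an at least 3.5-fold lower number from compound 2 to compound 3 (0.54 log units; beyond the scatter), on an aromatic carbon. The size of that step is only a floor, because compound 2 sits at a limit of the assay and has no true number: the limit of > 150000 nM in this assay, at which 1 of the 3 values shown sits. With 1-(3-hydroxyphenyl)-1H-1,2,3-triazol-4-yl in place of ethynyl, the step reads a 1.1-fold lower number from compound 1 to compound 3 (0.02 log units; within the scatter), so the hydroxy aryl triazole ester shows no readable difference from the propargyl ester.

From the compounds shown here alone, whether an amine or a methoxy group at this place would read like hydroxy stays open. Going by these compounds, the true size of the step away from trifluoromethyl also stays open.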